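The compounds below may be only part of what the source reports. "The series", "measured", "known", "first", "only" and "open" are said of these compounds alone.

Measured in a functional assay on HL-60 cells (Homo sapiens) for cytotoxicity, read by WST assay, with a stated time of 48 h; a lower number here means a stronger inhibitor, a higher number a weaker inhibitor:
Compound 1 `COc1cc(C(c2ccc(O)c(OC)c2)[C@H](C)[C@H](C)CO)ccc1O`: > 100000 nM, a limit
Compound 2 `COc1cc(C(c2ccc(O)c(OC)c2)[C@@H](CO)C(C)C)ccc1O`: > 100000 nM, a limit

Compound 2 has no exact number, and its > 100000 nM is only a limit of this assay. Among the measured compounds shown here, the series so far rests on (the limit of > 100000 nM in this assay, at which 2 of the 2 values shown sit).

Compound 3 `COC[C@@H](C(C)C)C(c1ccc(O)c(OC)c1)c1ccc(O)c(OC)c1` differs from compound 2 by methyl in place of hydrogen on an oxygen on a saturated carbon: hydroxymethyl becomes methoxymethyl, so the side chain reads 1-(methoxymethyl)-2-methylpropyl instead of 1-(hydroxymethyl)-2-methylpropyl.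

For the measured compounds named here, the only measured step is a step that the two limits leave unreadable from compound 1 to compound 2. It concerns a different change and offers no size to carry over, so no direction can be drawn from it. No step beyond the scatter is therefore expected in this assay, though the data cannot exclude one.

The expected change is a number no higher from compound 2 to compound 3 (the limit leaves the size open). Compound 3 is estimated at 100000 nM, with an expected range from 40000 nM to 200000 nM.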

Compound 3, half-maximal inhibitory concentration: 54000 nM
The estimate for compound 3 lay 1.9-fold (0.27 log units) above the measured number; measured number inside the range.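

In this assay compound 3, with methyl on this oxygen, gives the only exact number shown so far, 54000 nM. The change itself reads as an at least 1.8-fold lower number from compound 2 to compound 3 (0.26 log units; that floor lies within the scatter), and the wider change of side chain reads as an at least 1.8-fold lower number from compound 1 to compound 3 (0.26 log units; that floor lies within the scatter). Their true sizes stay open because the other values are limits: the limit of > 100000 nM in this assay, at which 2 of the 3 values shown sit.

On these data alone, whether an ethyl group on this oxygen, or an amine in place of the hydroxy group of the hydroxymethyl, would move the number further remains open. So does whether methyl on the same oxygen of the 2-(hydroxymethyl)-1-methylpropyl chain of compound 1 would have a similar effect.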